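Propylamino homologue of compound 1 in the V2 series

The source may hold more compounds than are shown below. What is called first, only, known or untested is meant among the compounds shown, and "the series" means these compounds.

Measured so far:
compound 1, `CNc1ccc(C(=O)N2CCCCc3ccccc32)c(Cl)c1` — 35 nM
compound 2, `CCNc1ccc(C(=O)N2CCCCc3cc(Cl)ccc32)c(Cl)c1` — 5 nM

Compound 1 stands at the higher of the two numbers in an assay on HeLa cells for binding affinity to Vasopressin V2 receptor (Homo sapiens); a higher number here means a weaker inhibitor, a lower number a stronger inhibitor; compound 2 gives the lower number, and the gap between them lies beyond the scatter. Compound 2 differs from compound 1 in more than one place, so no single step can be read from that pair.

Compound 3, `CCCNc1ccc(C(=O)N2CCCCc3ccccc32)c(Cl)c1`, carries ethyl in place of hydrogen on a saturated chain carbon bound to a nitrogen on an aromatic ring: methylamino becomes propylamino on the shared core of compound 1, with no other change. Within the data shown here, no measured step isolates this change. Among the measured compounds shown here, the only guidance is that the one compound with a longer chain on the aromatic nitrogen, compound 2, also gives the lower number in this assay, but that compound carries a further change as well.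

For compound 3 a modest shift toward a lower number is expected, a 1.8-fold lower number from compound 1 to compound 3 (0.24 log units; within the scatter), with a range wide enough to include no change. Compound 3 is estimated at 20 nM, between 6 nM and 60 nM.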

Compound 3, half-maximal inhibitory concentration: 18 nM
The estimate for compound 3 lay 1.1-fold (0.05 log units) above the measured number; measured number inside the range.
By their numbers in this assay, from the lowest: compound 2; then compounds 3 and 1 (each within the scatter of the next).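

In this assay, among these compounds, the one step that isolates this position reads a 1.9-fold lower number from compound 1 to compound 3 (0.29 log units; within the scatter). Methylamino to propylamino on the shared core of compound 1 therefore adds ethyl, 2 heavy atoms with no ring, without a shift that can be told apart from the scatter, so this position accepts the longer chain. No measurement bears on what lies behind this result.

Still open, going by these compounds, is whether a longer chain such as butyl, a branched chain such as isopropyl, or an amine or carboxylic acid at the chain end would move the number beyond the scatter. The steps to compound 2 cannot be read, as it differs from compound 1 and from compound 3 in more than one place.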